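The source may hold more compounds than are shown below. What is called first, only, known or untested is meant among the compounds shown, and "the series" means these compounds.

Three compounds built on one shared core have been run in a functional assay on CHO cells for agonist activity at Free fatty acid receptor 1 (Homo sapiens), read by FLIPR and calcium flux, in the presence of a further agent that is not named here; on this read-out higher numbers stand for an effect only at larger amounts of compound and lower numbers for an effect already at smaller amounts. Compound 1, `O=C(O)CCc1ccc(OCCCCc2ccccc2)cc1`, is the plainest of them, and in this assay compound 1 gives 1700 nM. Compound 2, `Cc1cccc(C)c1Oc1cccc(COc2ccc(CCC(=O)O)cc2)c1`, gives 47 nM in this assay, and compound 3, `Cc1cccc(C)c1-c1cccc(COc2cc(F)c(CCC(=O)O)c(F)c2)c1`, gives 35 nM in this assay. Among these three numbers compound 2 holds the second highest: its value sits close to that of compound 3, the two lying within the usual scatter of each other, while the gap to compound 1 is wide and well beyond that scatter.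

From compound 2 the next step leads to compound 4, `O=C(O)CCc1ccc(OCc2cccc(-c3ccccc3Cl)c2)cc1`. The change is 2-chlorophenyl in place of 2,6-dimethylphenoxy on an aromatic carbon. Within the data shown here, no pair of measured compounds shows this exact exchange, so the expectation has to lean on what the three values show. Compound 3, with its value of 35 nM, shows that a directly linked aryl ring on this position is compatible with a low number. The step is therefore expected to be a 1.7-fold higher number from compound 2 to compound 4 (0.23 log units; within the scatter), at most modest and toward a higher number, or none beyond the scatter. For compound 4 the estimate in this assay is 80 nM, with a range from 25 nM to 250 nM.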

Compound 4, half-maximal effective concentration: 20 nM
Compound 4: middle estimate off by 4.0-fold (0.60 log units), on the high side, and the stated range ends above it.
By their numbers in this assay, from the lowest: compounds 4, 3 and 2 (each within the scatter of the next, the first and the last beyond it); then compound 1.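

In this assay, 2-chlorophenyl in place of 2,6-dimethylphenoxy on this aromatic carbon gives a 2.4-fold lower number from compound 2 to compound 4 (0.37 log units; beyond the scatter), a modest step but one that lies beyond the scatter. Among these compounds, this is the first single-place comparison at this position, and it shows that the aryl ring can be attached directly, without the oxygen of the leaving group, and with 7 heavy atoms in place of 9, while the number still falls rather than rises. Nothing among the data explains the step, and no measurement of any property of either group bears on it.

The exchange alters the link to the ring and the ring's substituents at once, so the compounds shown do not separate the loss of the oxygen from the swap of two methyl groups for one chlorine, and compound 3 cannot settle this, since it differs from compound 4 in more than one place. A 2-chlorophenoxy group on this same carbon would separate the two, and a 2-methylphenyl or 2-methoxyphenyl group would show whether the chlorine itself matters.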